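A few compounds are considered here, and "the series" means these few. Any claim that something is new, unique, unknown or untested is made for them only; others in the source may bear on it.

Measured in a functional assay on MCF7 cells (Homo sapiens), read by MTT assay, with a stated time of 48 h; on this read-out higher numbers stand for weaker inhibition and lower numbers for stronger inhibition:

- Compound 1 `CCn1c(C(=O)NCCN(C)C)ccc1C(CC)(CC)c1ccc(OCC(=O)C(C)(C)C)c(C)c1` gives 520 nM
- Compound 2 `CCOC(=O)CN(C)C(=O)c1ccc(C(CC)(CC)c2ccc(OCC(O)C(C)(C)C)c(C)c2)n1CC` gives 9200 nM
- Compound 3 `CCN(CC)CCNC(=O)c1ccc(C(CC)(CC)c2ccc(OCC(O)C(C)(C)C)c(C)c2)n1CC` gives 690 nM

Among these three numbers, compound 3 at 690 nM lies within the usual scatter of compound 1 at 520 nM, so the two cannot be told apart. Both numbers sit far from compound 2 at 9200 nM, the weakest of the three on the values shown.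

The next compound to consider is compound 4 `CCn1c(C(=O)NCCN(C)C)ccc1C(CC)(CC)c1ccc(OCC(O)C(C)(C)C)c(C)c1`. It differs from compound 3 by one small edit at the end of the side chain: dimethylamino in place of diethylamino on a saturated chain carbon, two bonds along the chain from an amide-type nitrogen. In words, dimethylamino stands in place of diethylamino on a saturated chain carbon, two bonds along the chain from an amide-type nitrogen.

Within the data shown here, only one measured step bears on this edit, and only loosely. That step is a 13-fold lower number from compound 2 to compound 3 (1.12 log units; beyond the scatter), a large change, but it replaced the whole group on the carbonyl carbon, not just the end of a chain. The edit here keeps the chain and trims only its ends. Compound 1 carries the same 2-(dimethylamino)ethyl group on a core that is not identical, and its value of 520 nM offers a rough guide. Among the measured compounds shown here, no measured pair isolates this edit, so no step beyond the scatter is expected in this assay, and no direction can be firmly predicted.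

The expected step is small: a 1.2-fold lower number from compound 3 to compound 4 (0.06 log units; within the scatter).

For compound 4 the estimated value is 600 nM, with an expected range of 250 nM to 1400 nM.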

Compound 4, half-maximal inhibitory concentration: 660 nM
For compound 4 the middle estimate is 1.1-fold (0.04 log units) below the measured one, within the range that was stated.
By their numbers in this assay, from the lowest: compounds 1, 4 and 3 (each within the scatter of the next); then compound 2.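

In this assay, shortening the end of the side chain from diethylamino to dimethylamino, on a saturated chain carbon two bonds along the chain from an amide-type nitrogen, gives a 1.0-fold lower number from compound 3 to compound 4 (0.02 log units; within the scatter), so removing these carbons leaves the number within the scatter. The large step seen earlier is not tied to the diethylamino group, since (2-(dimethylamino)ethyl)amino in place of ((ethoxycarbonyl)methyl)(methyl)amino on the carbonyl carbon gives a 14-fold lower number from compound 2 to compound 4 (1.14 log units; beyond the scatter), and both amine-ended chains therefore stand well apart from compound 2. At the other end of the molecule, 1-hydroxy-2,2-dimethylpropyl in place of (tert-butyl)carbonyl gives a 1.3-fold higher number from compound 1 to compound 4 (0.10 log units; within the scatter), so this pair does not separate those two groups either.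

These compounds leave open whether the number would hold with a ring amine such as piperidine or morpholine at the chain end, with an unsubstituted primary amine there, or with a longer chain carrying the dimethylamino group. No measurement shown here offers an explanation for any of these steps.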